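A Furan Ring Replaces Hydroxyphenyl on a Hydrazone

A few compounds are considered here, and "the series" means these few. Any claim that something is new, unique, unknown or untested is made for them only; others in the source may bear on it.

Compound 2 `O=C(CSc1nnc(-c2ccncc2)o1)N/N=C/c1ccccc1O` and compound 1 `O=C(CSc1nnc(-c2ccncc2)o1)N/N=C/c1ccc(Cl)cc1` share the same core and differ only in the aromatic group attached to a carbon with a double bond to nitrogen. In an ADME assay on NIH3T3 cells (Mus musculus) for cytotoxicity, read by MTT assay, with a stated time of 24 h (a higher number here means a weaker inhibitor, a lower number a stronger inhibitor), compound 1 gives 181000 nM, while compound 2 gives 155000 nM. The step of a 1.2-fold lower number from compound 1 to compound 2 (0.07 log units; within the scatter) lies within the scatter, so although compound 2 holds the lower of the two numbers, the two compounds are indistinguishable on this measure, and both are very weak inhibitors of cell growth.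

Compound 3 `O=C(CSc1nnc(-c2ccncc2)o1)N/N=C/c1ccco1` has not yet been tested. It differs from compound 2 in one place: furan-2-yl in place of 2-hydroxyphenyl on a carbon with a double bond to nitrogen. Going by the values given here, the only measured step that bears on this change is a 1.2-fold lower number from compound 1 to compound 2 (0.07 log units; within the scatter), which swapped one aromatic ring for another at the same position and produced nothing beyond the scatter. On that basis, the step of a 1.1-fold higher number from compound 2 to compound 3 (0.04 log units; within the scatter) is expected to be no larger than the scatter in either direction. Compound 3 is therefore estimated to give about 170000 nM, with a likely range from 80000 nM to 360000 nM.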

Compound 3, half-maximal inhibitory concentration: 175000 nM
Beside the measured number, compound 3's estimate is 1.0-fold (0.01 log units) below it; measured number inside the range.
By their numbers in this assay, from the lowest: compounds 2, 3 and 1 (each within the scatter of the next).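

In this assay the swap of rings gives a 1.1-fold higher number from compound 2 to compound 3 (0.05 log units; within the scatter) and the swap from the chlorinated ring gives a 1.0-fold lower number from compound 1 to compound 3 (0.01 log units; within the scatter) so neither change moves the number beyond the scatter. Until now this position had held only six-membered rings of carbon, so the new information is that a smaller, five-membered aromatic ring with a hetero atom leaves the reading indistinguishable, even though furan-2-yl has fewer heavy atoms than 2-hydroxyphenyl and carries no hydrogen-bond donor. All three aromatic groups on this carbon therefore give the same result within the scatter, with no compound going against that, and nothing available here explains why the numbers stay so close.

On these data alone, these compounds all carry an aromatic ring at this position, so it remains open whether a group of a different kind, such as an amine, a carboxylic acid or a longer alkyl chain, would produce a step beyond the scatter. As far as these compounds go, it is also open whether this flat response holds in any other assay, since the comparison here rests on a single cell-based read-out.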